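Ester variation on a shared core: antiproliferative working notes

The source may hold more compounds than are shown below. What is called first, only, known or untested is meant among the compounds shown, and "the series" means these compounds.

Compound 1 `NC(=O)Cc1cc(Br)c(O)c(Br)c1` carries a hydrogen on an oxygen on the aromatic ring of the shared core. In a functional assay on PC-3 cells (Homo sapiens) for antiproliferative activity, read by MTT assay, with a stated time of 72 h (on this read-out higher numbers stand for weaker inhibition and lower numbers for stronger inhibition), compound 1 gives only a limit, > 100000 nM. Compound 2 `CC(=O)Oc1c(Br)cc(CC(N)=O)cc1Br` carries an acetyl in place of hydrogen on an oxygen on an aromatic ring. In this assay compound 2 likewise gives only a limit, > 100000 nM. The step that the two limits leave unreadable from compound 1 to compound 2 cannot be read because of the limit of > 100000 nM in this assay, at which 2 of the 2 values shown sit. Compound 3 `NC(=O)Cc1cc(Br)c(OC(=O)c2ccccc2)c(Br)c1` is not yet measured; it differs from compound 2 by phenyl in place of methyl on a carbonyl carbon. For the measured compounds named here, no measured step bears directly on this change, and the only step at hand is itself unreadable. Nothing among the values shown points to an inhibition that this assay would resolve as a number, so compound 3 is expected to return another limit. The estimate for compound 3 is 100000 nM, with a range from 30000 nM to 300000 nM. The step of a number no higher from compound 2 to compound 3 (the limit leaves the size open) implied by this estimate is expected to stay within the scatter.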

Compound 3, half-maximal inhibitory concentration: > 100000 nM
Compound 3: only a limit was reported (the forecaster's own chance of this, stated with the estimate: 80%); the middle value sits exactly at the limit.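

In this assay no step can be read between compound 2 and compound 3, because both give only limits: the limit of > 100000 nM in this assay, at which 3 of the 3 values shown sit.

The compounds shown leave open whether any ester on the shared core gives an inhibition that resolves as a number.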